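Working notes on the step to compound 3

A few compounds are considered here, and "the series" means these few. Any claim that something is new, unique, unknown or untested is made for them only; others in the source may bear on it.

Compound 1 `O=C(NCc1cccc2ccccc12)N1C(=O)c2ccccc2S1(=O)=O` gives 0.395 h as measured
Compound 2 `O=C(NCc1ccccc1Br)N1C(=O)c2ccccc2S1(=O)=O` gives 0.253 h as measured

In a physicochemical assay for pharmacokinetics (a higher number here means that the compound lasts longer, a lower number that the compound disappears faster), compound 2 stands within the scatter of compound 1, so neither can be placed ahead of the other on these two numbers. Compound 3 `COc1ccc(CNC(=O)N2C(=O)c3ccccc3S2(=O)=O)cc1` has not been measured. It has 4-methoxyphenyl in place of 2-bromophenyl on a saturated chain carbon bound to an amide-type nitrogen. Within the data shown here, no step between measured compounds that differ in one place is available, so the data do not show what such a change does in this assay. Among the measured compounds shown here, the only guide is the pair of values, compound 1 at 0.395 h and compound 2 at 0.253 h, which lie within the scatter of each other. No direction is expected, and the expected step of a 1.2-fold higher number from compound 2 to compound 3 (0.07 log units; within the scatter) stays within the scatter. For compound 3 the estimated half-life is 0.3 h, with an expected range from 0.13 h to 0.7 h in this series.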

Compound 3, half-life: 0.187 h
Estimate against measurement, compound 3: 1.6-fold (0.21 log units) above; measured number inside the range.
By their numbers in this assay, from the lowest: compounds 3, 2 and 1 (each within the scatter of the next, the first and the last beyond it).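

In this assay, among these compounds, putting 4-methoxyphenyl in place of 2-bromophenyl on a saturated chain carbon bound to an amide-type nitrogen gives a 1.4-fold lower number from compound 2 to compound 3 (0.13 log units; within the scatter), the first step that can be read at this position. The two groups therefore cannot be separated on half-life, even though 4-methoxyphenyl carries a hydrogen-bond acceptor and 2-bromophenyl carries none. Nothing available explains this result.

Still open, going by these compounds, is whether any group at this place can move the half-life beyond the scatter, for example a benzyl chain with a longer link to the aromatic ring, an amine or a carboxylic acid. Also open, on these data alone, is how unsubstituted phenyl would read against 2-bromophenyl and 4-methoxyphenyl, which would show whether either substituent matters on its own.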